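The source may hold more compounds than are shown below. What is called first, only, known or untested is meant among the compounds shown, and "the series" means these compounds.

Measured compounds:
compound 1 `COc1cc(N2C(N)=C(C#N)C(c3ccccc3O)C3=C2CC(C)(C)CC3=O)cc(OC)c1OC` — 10%
compound 2 `COc1cc(N2C(N)=C(C#N)C(c3ccc(C)cc3)C3=C2CC(C)(C)CC3=O)cc(OC)c1OC` — 90%

In a functional assay on Ehrlich cells (Mus musculus) for cytotoxicity, tested at 100 ug/mL (on this read-out higher numbers stand for a stronger effect at the one concentration tested and lower numbers for a weaker effect), compound 2 gives 90%, the higher of the two numbers; compound 1 gives 10%. Among the measured compounds shown here, the only step known is a number 80 percentage points higher from compound 1 to compound 2 (beyond the scatter). Compound 3 `COc1cc(N2C(N)=C(C#N)C(c3ccccc3Cl)C3=C2CC(C)(C)CC3=O)cc(OC)c1OC` differs from compound 2 by 2-chlorophenyl in place of 4-methylphenyl on a saturated ring carbon. For the measured compounds named here, no measured step matches this change; the step from compound 1 to compound 2 shows only that the group on the saturated ring carbon can move this assay strongly, with 2-hydroxyphenyl low and 4-methylphenyl high. Going by the values given here, a 2-chlorophenyl has no precedent, so a step of moderate size in either direction is possible. Compound 3 is expected at 55% (range 15% to 95%), an expected step of a number 35 percentage points lower from compound 2 to compound 3 (beyond the scatter).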

Compound 3, a percentage reported as activity, at one concentration (the size of the read-out at that concentration, not a potency): 20%
Beside the measured number, compound 3's estimate is 35 percentage points above it, and the stated range covers the measured number.
By their numbers in this assay, from the lowest: compounds 1 and 3 (each within the scatter of the next); then compound 2.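

In this assay, 2-chlorophenyl in place of 4-methylphenyl on the saturated ring carbon gives a number 70 percentage points lower from compound 2 to compound 3 (beyond the scatter) and so shows that the high reading does not extend to every substituted phenyl here. Chloro in place of hydroxy on the aromatic carbon gives a number 10 percentage points higher from compound 1 to compound 3 (within the scatter) and leaves 2-chlorophenyl and 2-hydroxyphenyl indistinguishable on this read-out. No available evidence bears on the origin of these differences.

Compound 2 and compound 3 differ in both the substituent and its name-given ring position, so the two contributions cannot be separated. A 2-methylphenyl or 4-chlorophenyl would separate them, while a 4-methoxyphenyl or 4-aminophenyl would test other groups.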